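A Cyano-for-Trifluoromethyl Swap Tested Against Growth Limits

This account rests on a few compounds, and the source may have more. Where it says the series, first, only, none or still open, it means among the compounds named here.

Compound 1 `Cc1cc(=O)oc2cc(SCc3cccc(C(F)(F)F)c3)ccc12` and compound 2 `Cc1cc(=O)oc2cc(SCc3cccc(C#N)c3)ccc12` share one core, while compound 3 `CCc1cc(=O)c2ccc(OCc3cccc(C(F)(F)F)c3)c(C)c2o1` and compound 4 `CCc1cc(=O)c2ccc(OCc3cccc(C#N)c3)c(C)c2o1` share another; the difference between the two cores is not broken down here. The three measured compounds were tested in a functional assay on KB cells (Homo sapiens) for antiproliferative activity, read by sulforhodamine B assay, with a stated time of 72 h; a lower number here means a stronger inhibitor of growth, a higher number a weaker inhibitor of growth. Compound 1 reaches only the limit of the assay, > 28500 nM, rather than a number. Compound 2 likewise returns a limit, > 32500 nM. Compound 3 too gives a limit, > 27600 nM. The change from compound 1 to compound 2 is cyano in place of trifluoromethyl on an aromatic carbon, and the step that the two limits leave unreadable from compound 1 to compound 2 cannot be read, as both ends are limits. The values behind that judgement are the limit of > 28500 nM in this assay, at which 1 of the 3 values shown sits, and (the limit of > 32500 nM in this assay, at which 1 of the 3 values shown sits); the third limit, (the limit of > 27600 nM in this assay, at which 1 of the 3 values shown sits), belongs to compound 3.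

Compound 4 differs from compound 3 by the same change, (cyano in place of trifluoromethyl on an aromatic carbon), made on the other core. The measured pair shows only that both partners lie beyond the reach of this assay, and compound 3 stands at the same kind of limit. On that basis the expected step from compound 3 to compound 4 is a step that the limit leaves unreadable from compound 3 to compound 4, resting on the unreadable a step that the two limits leave unreadable from compound 1 to compound 2. Compound 4 is therefore expected to sit at 40000 nM in this assay, most likely reported again only as a limit, with an expected range from 15000 nM to 150000 nM.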

Compound 4, concentration for 50% growth inhibition: > 31300 nM
Compound 4 gave a limit, no number; the forecaster's own chance of this, stated with the estimate: 85%; the middle value is on the limit's open side.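

In this assay compound 4 gives only a limit, > 31300 nM. Compound 3 is also only a limit, > 27600 nM, so no step can be read between compound 3 and compound 4. The compounds shown leave open how strongly any of the four inhibits growth, and whether cyano in place of trifluoromethyl changes that on either core.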